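A Methyl Removed from an Aromatic Oxygen: Compound 3 to 4

A few compounds are considered here, and "the series" means these few. Any claim that something is new, unique, unknown or untested is made for them only; others in the source may bear on it.

Of the compounds shown here, three have been tested in an ADME assay for cytotoxicity, with Mus musculus as the target, with a stated time of 48 h; on this read-out lower numbers stand for stronger inhibition and higher numbers for weaker inhibition. Compound 1 `COc1cc2c(c(OC)c1-c1c(C)cc3cccc(OC)c3c1O)C(C)=N[C@@H](C)C2` reaches only the limit of the assay, > 100000 nM. Compound 2 `COc1c2c(cc(O)c1-c1c(C)cc3cccc(OC)c3c1O)C[C@H](C)N=C2C` gives 29900 nM in this assay. Compound 3 `COc1cc(C)c(-c2ccc3cc(C)nc(C)c3c2O)c2cccc(O)c12` gives 34800 nM in this assay, a value that sits within the scatter of compound 2, so the two cannot be told apart. The third value, that of compound 1, is a limit rather than a number.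

Compound 4 `Cc1cc2ccc(-c3c(C)cc(O)c4c(O)cccc34)c(O)c2c(C)n1` differs from compound 3 in one place: hydrogen in place of methyl on an oxygen on an aromatic ring. The same change has been measured once before, from compound 1 to compound 2, where it brought an at least 3.3-fold lower number from compound 1 to compound 2 (0.52 log units; beyond the scatter). Because compound 1 sat at the limit of > 100000 nM in this assay, at which 1 of the 3 values shown sits, the true size of that step is known only as a lower bound. On that single precedent, a lower number of at least modest size is expected when the methyl is removed from compound 3 as well. The step expected from this change is a 2.3-fold lower number from compound 3 to compound 4 (0.37 log units; beyond the scatter). Compound 4 is therefore estimated to give about 15000 nM in this assay, with a likely range from 5000 nM to 40000 nM.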

Compound 4, half-maximal inhibitory concentration: > 100000 nM
Compound 4: no number, only a limit (the forecaster's own chance of this, stated with the estimate: 5%); at least 6.6-fold (0.82 log units) between middle value and limit.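

In this assay, going by these compounds alone, the change from methoxy to hydroxy on an aromatic ring now brings an at least 2.8-fold higher number from compound 3 to compound 4 (0.45 log units; beyond the scatter) and so moves the read-out towards weaker inhibition, whereas the only earlier example moved it towards stronger inhibition. The change therefore has no single direction in this series, and what it does depends on the core that carries it, as far as these two pairs can show: the same change on two cores in this assay, an at least 3.3-fold lower number (0.52 log units; beyond the scatter) from compound 1 to compound 2 and an at least 2.8-fold higher number (0.45 log units; beyond the scatter) from compound 3 to compound 4, at least 9.6-fold (0.98 log units) apart, beyond the scatter of two such steps. Neither step has a known true size, only a lower bound, since compound 1 and compound 4 each stop at a limit of the assay and not at a number: the limit of > 100000 nM in this assay, at which 2 of the 4 values shown sit.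

Two pairs cannot show which feature of the cores decides the direction, or how far compound 4 really lies from compound 3. Also open, on these data alone, is how the read-out would respond on either core if this oxygen carried a longer chain, as in an ethoxy or propoxy group, or if an amine stood in place of the hydroxy group.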